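The source may hold more compounds than are shown below. What is called first, only, known or untested is meant among the compounds shown, and "the series" means these compounds.

Measured so far:
- Compound 1 `Cc1ccccc1CN1CCc2c(sc(NC(=O)c3ccccc3Cl)c2C(N)=O)C1`: > 50000 nM (a limit)
- Compound 2 `NC(=O)c1c(NC(=O)c2ccccc2Cl)sc2c1CCN(Cc1ccc(Cl)cc1Cl)C2`: 16300 nM

Within the data shown here, in a functional assay on MKN-74 cells (Homo sapiens) for antiproliferative activity, with a stated time of 24 h (a lower number here means a stronger inhibitor, a higher number a weaker inhibitor), compound 2 gives 16300 nM, the only number so far. Compound 1 reads > 50000 nM, which is a limit. Compound 3 `NC(=O)c1c(NC(=O)c2ccccc2Cl)sc2c1CCN(C(=S)Nc1ccccc1)C2` changes the group on the amine nitrogen in a ring: a group of 9 heavy atoms (7 carbon, 1 nitrogen, 1 sulfur; one six-membered aromatic ring of carbon only) in place of a group of 9 heavy atoms (7 carbon, 2 chlorine; one six-membered aromatic ring of carbon only), on an amine nitrogen in a ring. Among the measured compounds shown here, the one measured step, an at least 3.0-fold lower number from compound 1 to compound 2 (0.48 log units; beyond the scatter), sits at that same nitrogen. The group there carries no chlorine in compound 1 or compound 3, so a move of similar modest size back towards weaker values is expected. The estimated step is a 1.7-fold higher number from compound 2 to compound 3 (0.23 log units; within the scatter). Compound 3 is estimated at 28000 nM, with an expected range of 9000 nM to 70000 nM.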

Compound 3, half-maximal inhibitory concentration: 15600 nM
Compound 3: middle estimate off by 1.8-fold (0.25 log units), on the high side, within the range that was stated.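

In this assay, replacing 2,4-dichlorobenzyl on the amine nitrogen in a ring with the chlorine-free group containing nitrogen and sulfur leaves the read-out unchanged within the scatter: a 1.0-fold lower number from compound 2 to compound 3 (0.02 log units; within the scatter). The gain over the group of compound 1 therefore does not require chlorine: an at least 3.2-fold lower number from compound 1 to compound 3 (0.50 log units; beyond the scatter). That step rests on a limit for compound 1: the limit of > 50000 nM in this assay, at which 1 of the 3 values shown sits.

Still open, going by these compounds, is whether a carboxylic acid or a longer chain ending in an amine at this nitrogen would give a clearly lower number. The compounds shown also leave open what the shared core contributes.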